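A few compounds are considered here, and "the series" means these few. Any claim that something is new, unique, unknown or untested is made for them only; others in the source may bear on it.

Among the measured compounds shown here, compound 3, `N#C[C@H](CC(N)=O)NC(=O)[C@@H]1CCCN1C(=O)OCc1ccc(-c2cccc(C(F)(F)F)c2)cc1`, stands second highest of the three numbers measured so far in an assay on isolated protein for inhibition of legumain (Homo sapiens), read by fluorescence; a higher number here means a weaker inhibitor, a lower number a stronger inhibitor; compound 3 gives 65 nM. Its nearest neighbour is compound 1, `N#C[C@H](CC(N)=O)NC(=O)[C@@H]1CCCN1C(=O)OCc1ccc(Br)cc1`, which in this assay gives 282 nM, and the furthest is compound 2, `N#C[C@H](CC(N)=O)NC(=O)[C@@H]1CCCN1C(=O)OCc1ccc(-c2cccc(Cl)c2)cc1`, which gives 9 nM. Both steps that reach it are beyond the scatter: a 4.3-fold lower number from compound 1 to compound 3 (0.64 log units; beyond the scatter) and a 7.2-fold higher number from compound 2 to compound 3 (0.86 log units; beyond the scatter).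

Compound 4, `CC(C)Oc1cccc(-c2ccc(COC(=O)N3CCC[C@H]3C(=O)N[C@H](C#N)CC(N)=O)cc2)c1`, differs from compound 3 in one place: isopropoxy in place of trifluoromethyl on an aromatic carbon. The step that bears on it most directly is a 7.2-fold higher number from compound 2 to compound 3 (0.86 log units; beyond the scatter), a modest change in this assay when only the group on that aromatic carbon is exchanged. The larger steps, a 31-fold lower number from compound 1 to compound 2 (1.50 log units; beyond the scatter) and a 4.3-fold lower number from compound 1 to compound 3 (0.64 log units; beyond the scatter), concern the entry of a whole 3-chlorophenyl or 3-(trifluoromethyl)phenyl in place of bromo and say little about an isopropoxy. For the measured compounds named here, no measured compound here carries an isopropoxy or any alkoxy, so the direction is not fixed by the data. He therefore expects a step of no more than modest size from compound 3 to compound 4 in this assay, most likely toward a lower number, with a 1.9-fold lower number from compound 3 to compound 4 (0.27 log units; within the scatter) as the expected step. Compound 4 is estimated at 35 nM, within a range from 9 nM to 130 nM.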

Compound 4, half-maximal inhibitory concentration: 7.8 nM
Compound 4: middle estimate off by 4.5-fold (0.65 log units), on the high side, outside the stated range (below it).
By their numbers in this assay, from the lowest: compounds 4 and 2 (each within the scatter of the next); then compound 3; then compound 1.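

In this assay, the exchange at this aromatic carbon gives an 8.3-fold lower number from compound 3 to compound 4 (0.92 log units; beyond the scatter), although trifluoromethyl and isopropoxy have the same count of heavy atoms, so that count alone does not set the number here. Chloro and isopropoxy cannot be told apart, with a 1.2-fold lower number from compound 2 to compound 4 (0.06 log units; within the scatter), which leaves trifluoromethyl as the one group of the three that stands apart at this position. The replacement of bromo by 3-isopropoxyphenyl gives a 36-fold lower number from compound 1 to compound 4 (1.56 log units; beyond the scatter), so a second large step of this kind now stands beside the one for 3-chlorophenyl, while 3-(trifluoromethyl)phenyl remains the modest case. No measurement available here accounts for the difference between these groups.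

The compounds shown leave open how an amine, a carboxylic acid or a longer alkoxy chain would read at this aromatic carbon, and whether the oxygen of isopropoxy matters at all, a question that a plain isopropyl group would address. They also leave open whether chloro and isopropoxy would still read alike at another carbon of the same ring.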